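The source may report more compounds than this note shows. Statements on the series, on what has been measured and on what is new or still open speak of the compounds shown alone.

Three compounds have been measured in a physicochemical assay for solubility, read by HPLC, in phosphate buffer, measured as kinetic solubility, at pH 7.4; a lower number here means a less soluble compound, a higher number a more soluble compound:

Compound 1, `CCC(=O)c1cc(-c2ccc(C)cc2)n(-c2ccc(S(N)(=O)=O)cc2)c1C`, gives 1000 nM.
Compound 2, `CCOC(=O)c1cc(-c2ccc(C)cc2)n(-c2ccc(S(N)(=O)=O)cc2)c1C`, gives 1300 nM.
Compound 3, `CCC(=O)c1cc(-c2ccc(F)cc2)n(-c2ccc(S(N)(=O)=O)cc2)n1`, gives 88900 nM.

Compound 1 and compound 2 share one core and differ in a single place: ethoxy in place of ethyl on a carbonyl carbon. That change gave a 1.3-fold higher number from compound 1 to compound 2 (0.11 log units; within the scatter), so in this assay the two compounds cannot be told apart. Compound 3 is built on a different core; the difference between the two cores is not broken down here. Compound 3 gives the highest number of the three, and its distance from both compound 1 and compound 2 lies beyond the scatter.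

Compound 4, `CCOC(=O)c1cc(-c2ccc(F)cc2)n(-c2ccc(S(N)(=O)=O)cc2)n1`, has not yet been measured. It differs from compound 3 by ethoxy in place of ethyl on a carbonyl carbon, the same change seen between compound 1 and compound 2, at a place described in the same words. Because that earlier change produced a 1.3-fold higher number from compound 1 to compound 2 (0.11 log units; within the scatter), the step from compound 3 to compound 4 is expected to be similarly small, at about a 1.1-fold higher number from compound 3 to compound 4 (0.05 log units; within the scatter). Compound 4 is therefore estimated to give 100000 nM in this assay, most likely between 45000 nM and 220000 nM.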

Compound 4, solubility: 56400 nM
Compound 4: the middle estimate sits 1.8-fold (0.25 log units) above what was measured, within the range that was stated.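

In this assay putting ethoxy in place of ethyl on a carbonyl carbon gives a 1.6-fold lower number from compound 3 to compound 4 (0.20 log units; within the scatter) while the same change on the core of compound 1 gives a 1.3-fold higher number from compound 1 to compound 2 (0.11 log units; within the scatter) and so the two compounds in each pair cannot be told apart. The change therefore carries from one core to the other as a step too small to read, and the opposite directions printed for the two steps carry no meaning at this size. Two pairs do not make a rule for any further core, and no measurement at hand bears on why the step stays this small on both.

The compounds shown leave open whether a different group on the same carbonyl carbon, such as an amine, a hydroxyl that would make a carboxylic acid, or a longer chain such as butyl, would give a step beyond the scatter on either core. They also leave open whether the swap of ethyl for ethoxy would stay this small on a third core.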